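Amide hydrogen in place of ethyl: outlook for compound 4

This account rests on a few compounds, and the source may have more. Where it says the series, first, only, none or still open, it means among the compounds named here.

compound 1 `CCN(C(=O)c1cc(C(C)C)c(O)cc1O)c1ccc(NC(=O)CCCCCCC(=O)NO)cc1` gives 5630 nM
compound 2 `CC(C)c1cc(C(=O)Nc2cccc(NC(=O)CCCCCCC(=O)NO)c2)c(O)cc1O` gives > 10000 nM (a limit)
compound 3 `CC(C)c1cc(C(=O)N(C)c2ccc(NC(=O)CCCCCCCCC(=O)NO)cc2)c(O)cc1O` gives 1080 nM

In a functional assay on A549 cells (Homo sapiens) for inhibition, read by sulforhodamine B assay, with a stated time of 48 h (on this read-out lower numbers stand for stronger inhibition of growth and higher numbers for weaker inhibition of growth), compound 1 has the higher of the two true numbers, and compound 3 lies lower, beyond the usual scatter. Compound 4 `CC(C)c1cc(C(=O)Nc2ccc(NC(=O)CCCCCCC(=O)NO)cc2)c(O)cc1O` carries hydrogen in place of ethyl on an amide-type nitrogen. Within the data shown here, no measured step isolates this change. A small rise in the number is expected, perhaps none beyond the scatter. This expectation leans on compound 2 (> 10000 nM), which also has the amide hydrogen and gives only a limit. The expected step is a 1.4-fold higher number from compound 1 to compound 4 (0.15 log units; within the scatter) ( an estimate ). For compound 4 the estimated value is 8000 nM ( expected range 3000 nM to 20000 nM).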

Compound 4, concentration for 50% growth inhibition: > 10000 nM
Compound 4 gave a limit, no number (the forecaster's own chance of this, stated with the estimate: 40%); middle value at least 1.2-fold (0.09 log units) from the limit.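

In this assay compound 4 gives > 10000 nM, which is a limit and not a number. Among these compounds, this is the first step that isolates the ethyl on the amide-type nitrogen: hydrogen in its place gives an at least 1.7-fold higher number from compound 1 to compound 4 (0.24 log units; that floor lies within the scatter), so the step has a floor but no measured size, and a change beyond the scatter is not established. The full size cannot be read because the read-out stops at a limit: the limit of > 10000 nM in this assay, at which 2 of the 4 values shown sit.

Still open, from the compounds shown here alone, is how a propyl or benzyl group on this nitrogen would read. Also open, going by these compounds, is whether the amide hydrogen would give a number alongside a longer chain.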